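The source may report more compounds than this note shows. Statements on the series, on what has been measured and on what is new or still open speak of the compounds shown alone.

Measured so far in an ADME assay on HEK293 cells (Homo sapiens) for inhibition, read by MTT assay, with a stated time of 2 days; a lower number here means a stronger inhibitor, a higher number a weaker inhibitor:

compound 1, `COc1ccccc1/C=C/c1ccccc1O`: 15 ug/mL
compound 2, `COc1ccccc1/C=C/c1cccc(O)c1`: 24 ug/mL
compound 3, `COc1ccccc1/C=C/c1ccccc1N`: 2.1 ug/mL

Compound 1 and compound 2 are built from the same atoms joined differently; the difference between the two cores is not broken down here. Their values in this assay lie within the usual scatter of each other. Compound 3 differs from compound 1 by one change, (amino in place of hydroxy on an aromatic carbon), and that change gave a 7.1-fold lower number from compound 1 to compound 3 (0.85 log units; beyond the scatter).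

Compound 4, `COc1ccccc1/C=C/c1cccc(N)c1`, has not yet been measured in this assay. It differs from compound 2 by amino in place of hydroxy on an aromatic carbon. Among the compounds with values here, this is the same kind of change as the one from compound 1 to compound 3, but the place is not the same: there the group sat ortho to a large group, here it sits meta to a large group. Because a 7.1-fold lower number from compound 1 to compound 3 (0.85 log units; beyond the scatter) was a modest step beyond the scatter, a step of similar direction is expected here, estimated as a 6.0-fold lower number from compound 2 to compound 4 (0.78 log units; beyond the scatter), with some allowance for the different place. For compound 4 the value expected in this assay is 4 ug/mL, estimated between 1.5 ug/mL and 12 ug/mL.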

Compound 4, half-maximal inhibitory concentration: 45 ug/mL
Compound 4: the middle estimate sits 11-fold (1.05 log units) below what was measured, outside the stated range (above it).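

Putting amino in place of hydroxy on the core of compound 2 in this assay gave a 1.9-fold higher number from compound 2 to compound 4 (0.27 log units; within the scatter). Set beside the earlier step, the same swap did not carry over from one core to the other: the same change on two cores in this assay, a 7.1-fold lower number (0.85 log units; beyond the scatter) from compound 1 to compound 3 and a 1.9-fold higher number (0.27 log units; within the scatter) from compound 2 to compound 4, 13-fold (1.13 log units) apart, beyond the scatter of two such steps. This shows that, in this small series, the large step seen on the core of compound 1 cannot be used as a rule for the same swap on a related core, but two pairs alone do not show why the steps differ or how the swap would behave on any further core.

The compounds shown leave open whether other groups at the same place, such as a methyl group, a fluorine atom or a carboxylic acid, would follow the hydroxy and amino compounds or part from them. They also leave open whether the contrast between the two cores would hold for a longer chain on the nitrogen, such as an ethylamino group.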